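The compounds below may be only part of what the source reports. "The series", "measured", "known", "first", "only" and "open" are said of these compounds alone.

Compound 3 `Cc1ccc(C2=NN(c3nc(-c4ccc(C#N)cc4)cs3)C(c3ccc(F)cc3)C2)s1` gives 250 ug/mL in an ADME assay on NIH3T3 cells (Mus musculus) for cytotoxicity, read by XTT assay, with a stated time of 24 h; on this read-out lower numbers stand for stronger inhibition and higher numbers for weaker inhibition. Among the numbers shown it stands highest, yet its nearest neighbour, compound 2 `COc1ccc(-c2csc(N3N=C(c4ccc(C)s4)CC3c3ccc(F)cc3)n2)cc1`, gives 147 ug/mL, and the gap a 1.7-fold higher number from compound 2 to compound 3 (0.23 log units; within the scatter) lies within the scatter, so the two are not separable. Compound 1 `Cc1ccc(-c2csc(N3N=C(c4ccc(C)s4)CC3c3ccc(F)cc3)n2)cc1` is reported only as a limit, > 500 ug/mL. That ceiling is the limit of > 500 ug/mL in this assay, at which 1 of the 3 values shown sits, and it is the reason the two steps leading away from compound 1 are floors rather than numbers.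

Compound 4 `Cc1ccc(C2=NN(c3nc(-c4ccccc4)cs3)C(c3ccc(F)cc3)C2)s1` differs from compound 3 by hydrogen in place of cyano on an aromatic carbon. The step that bears most directly on this change is the one at the same position, an at least 2.0-fold lower number from compound 1 to compound 3 (0.30 log units; that floor lies within the scatter), which reached only a floor within the scatter. The other change at that position, an at least 3.4-fold lower number from compound 1 to compound 2 (0.53 log units; beyond the scatter), was beyond the scatter, but methoxy is not involved here. Taking the cyano away in compound 4 therefore points back toward the range occupied by compound 1, and the expected step is a modest rise in number, a 1.4-fold higher number from compound 3 to compound 4 (0.15 log units; within the scatter), with a fair chance that this assay again returns only a limit. For compound 4 the estimated value in this assay is 350 ug/mL, expected to fall between 150 ug/mL and 800 ug/mL.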

Compound 4, half-maximal inhibitory concentration: > 500 ug/mL
Compound 4 was reported as a limit (the forecaster's own chance of this, stated with the estimate: 35%); middle value at least 1.4-fold (0.15 log units) away from the limit.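

Hydrogen at this place gives the series the plain phenyl reference it lacked in this assay, and methoxy separates from that reference beyond the scatter, with an at least 3.4-fold higher number from compound 2 to compound 4 (0.53 log units; beyond the scatter). The nitrile does not show the same separation: an at least 2.0-fold higher number from compound 3 to compound 4 (0.30 log units; that floor lies within the scatter) is only a floor, so among the groups shown only methoxy stands clear of both hydrogen and methyl, and compound 3 goes against any reading that a group at this place in general lowers the number. Compound 4 is reported only as a limit, like compound 1, and the step between those two cannot be read: the limit of > 500 ug/mL in this assay, at which 2 of the 4 values shown sit.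

Among these compounds, how far hydrogen, methyl and the nitrile truly lie from one another stays hidden behind that limit, so the series so far supports one clear separation, not a trend across groups. On these data alone, whether a hydroxyl, an amine or a carboxylic acid at this place would separate from hydrogen as methoxy does, or stay unseparated as the nitrile does, remains open.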